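A few compounds are considered here, and "the series" means these few. Any claim that something is new, unique, unknown or untested is made for them only; others in the source may bear on it.

Working notes on the oxazolidinone amide series.

Of the compounds shown here, two carry numbers so far. Compound 1, `CCCCCCOc1ccc(C(=O)N2CCOC2=O)cc1`, in an assay on HEK293 cells for inhibition of N-acylethanolamine-hydrolyzing acid amidase (Rattus norvegicus), read by LC-MS, with a stated time of 30 min (a lower number here means a stronger inhibitor, a higher number a weaker inhibitor), gives 640 nM. Compound 2, `Cc1ccccc1CCCCCC(=O)N1CCOC1=O`, is a different case: in this assay compound 2 gives > 20000 nM, and this is a limit of the assay, not a number. Compound 2 therefore stands at the limit of > 20000 nM in this assay, at which 1 of the 2 values shown sits, so its position relative to compound 1 cannot be placed more closely than that.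

The next step is from compound 2 to compound 3, `O=C(CCCCCc1ccccc1Cl)N1CCOC1=O`. The change is chloro in place of methyl on an aromatic carbon, at a position ortho to a large group. Within the data shown here, no measured pair differs in just this way, so there is no step to lean on; the swap exchanges one heavy atom for another without altering ring count, donors or acceptors.

In this assay the step from compound 2 to compound 3 is expected to be a number no higher from compound 2 to compound 3 (the limit leaves the size open), which is to say none beyond the scatter in either direction. For compound 3 the estimate in this assay is 20000 nM, with a range from 5000 nM to 60000 nM, and a fair chance that only a limit is reported again.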

Compound 3, half-maximal inhibitory concentration: > 20000 nM
Compound 3 gave a limit, no number; the forecaster's own chance of this, stated with the estimate: 60%; the middle value sits exactly at the limit.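

Compound 2 and compound 3 both end at a limit of the assay rather than a number, so no step between them can be read: the limit of > 20000 nM in this assay, at which 2 of the 3 values shown sit.

The compounds shown leave open whether chloro in place of methyl on an aromatic carbon changes inhibition at all in this assay.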